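Bromo in place of methylcarbamoyl on the shared core

The compounds below may be only part of what the source reports. "The series", "measured", "known", "first", "only" and "open" are said of these compounds alone.

In an ADME assay on J774 cells (Mus musculus) for cytotoxicity (on this read-out lower numbers stand for an effect already at smaller amounts and higher numbers for an effect only at larger amounts of compound), compound 1 `CCCCc1cc2c(=O)c(CC)c[nH]c2cc1OCCOc1ccccc1` gives 360 nM. Compound 2 `CCCCc1cc2c(=O)c(C(=O)NC)c[nH]c2cc1OCCOc1ccccc1` gives > 20000 nM, which is a limit of the assay and not a number, so it has no exact place on the scale.

Compound 3 `CCCCc1cc2c(=O)c(Br)c[nH]c2cc1OCCOc1ccccc1` carries bromo in place of methylcarbamoyl on an aromatic carbon. Among the compounds with values here, one measured step bears on this change: an at least 55-fold higher number from compound 1 to compound 2 (1.74 log units; beyond the scatter), where methylcarbamoyl replaced ethyl at the same place. Compound 3 loses that methylcarbamoyl, although bromo rather than ethyl enters. A large step to a lower number is therefore expected in this assay, resting on this single step, with compound 1 at 360 nM as the guide. The expected step is an at least 25-fold lower number from compound 2 to compound 3 (1.39 log units; beyond the scatter). For compound 3 the estimate is 800 nM, with an expected range from 200 nM to 5000 nM.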

Compound 3, half-maximal effective concentration: 8070 nM
Compound 3: middle estimate off by 10-fold (1.00 log units), on the low side; measured number above the stated range.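

At this aromatic carbon in this assay, bromo in place of ethyl already gives a 22-fold higher number from compound 1 to compound 3 (1.35 log units; beyond the scatter), so a high number is not tied to methylcarbamoyl alone. Bromo in place of methylcarbamoyl gives an at least 2.4-fold lower number from compound 2 to compound 3 (0.39 log units; beyond the scatter), which shows that the two groups that replace ethyl here do not give the same result. The full size of that second step stays unknown, since the value of compound 2 is a limit of the assay and not a number: the limit of > 20000 nM in this assay, at which 1 of the 3 values shown sits.

The compounds shown leave open where a longer chain, an amine or a carboxylic acid at this carbon would fall in this assay. They therefore cannot tell whether the low number of compound 1 is particular to ethyl or shared with other groups.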